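The source may report more compounds than this note shows. Statements on the series, on what has been measured and on what is new or still open speak of the compounds shown alone.

Compound 1 `CCO[C@H]1C[C@@H](c2coc3ccc(F)cc3c2=O)N(c2ccccc2)O1` and compound 3 `CCO[C@H]1C[C@@H](c2coc3ccc(C)cc3c2=O)N(c2ccccc2)O1` share one core and differ only by methyl in place of fluoro on an aromatic carbon. In a functional assay on A549 cells (Homo sapiens) for inhibition, read by sulforhodamine B assay, with a stated time of 48 h (a lower number here means a stronger inhibitor, a higher number a weaker inhibitor), compound 1 gives 26400 nM, while compound 3 gives 20700 nM, so that a 1.3-fold lower number from compound 1 to compound 3 (0.11 log units; within the scatter). Compound 2 `O=C1[C@H]2[C@H](ON(c3ccccc3)[C@@H]2c2coc3ccc(F)cc3c2=O)C(=O)N1c1ccccc1` has a different core; how that core differs from the core of compound 1 is not broken down here. In this assay compound 2 gives 13500 nM, which lies within the scatter of both compound 1 and compound 3. Compound 4 `Cc1ccc2occ([C@@H]3[C@H]4C(=O)N(c5ccccc5)C(=O)[C@H]4ON3c3ccccc3)c(=O)c2c1` is still to be measured and differs from compound 2 by methyl in place of fluoro on an aromatic carbon, the same change already seen from compound 1 to compound 3. Because a 1.3-fold lower number from compound 1 to compound 3 (0.11 log units; within the scatter) stayed within the scatter, the step of a 1.3-fold lower number from compound 2 to compound 4 (0.11 log units; within the scatter) is expected to be small as well. Compound 4 is therefore estimated at 10500 nM, between 4000 nM and 28000 nM.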

Compound 4, half-maximal inhibitory concentration: > 60000 nM
Compound 4 was reported as a limit (the forecaster's own chance of this, stated with the estimate: 10%); at least 5.7-fold (0.75 log units) between middle value and limit.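

In this assay, methyl in place of fluoro gives an at least 4.4-fold higher number from compound 2 to compound 4 (0.64 log units; beyond the scatter), so the small step seen on the core of compound 1 did not carry over to the core of compound 2: the same change on two cores in this assay, a 1.3-fold lower number (0.11 log units; within the scatter) from compound 1 to compound 3 and an at least 4.4-fold higher number (0.64 log units; beyond the scatter) from compound 2 to compound 4, at least 5.6-fold (0.75 log units) apart, beyond the scatter of two such steps. For compound 4, > 60000 nM is a limit of the assay and not a number: the limit of > 60000 nM in this assay, at which 1 of the 4 values shown sits. With one pair on each core, this shows that the step cannot be assumed to carry from one core to the other in this series, but it does not show how large the step on the core of compound 2 truly is or why the two cores differ.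

The compounds shown leave open how chloro, methoxy or an amine in the same place would behave on either core. They also leave open whether any other change would carry across these two cores.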